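The source may report more compounds than this note shows. Statements on the series, on what has been measured and on what is new or still open speak of the compounds shown alone.

Measured so far:
- compound 1, `Cc1cc(NC(=O)Nc2ccc(Cl)c(Cl)c2)c2ccccc2n1`: in an ADME assay on HepG2 cells (Homo sapiens) for cytotoxicity, with a stated time of 72 h (a higher number here means that more compound is needed for the effect, a lower number that less compound is needed), compound 1 gives 17000 nM
- compound 2, `Cc1cc(NC(=O)Nc2ccc(C(F)(F)F)cc2)c2ccccc2n1`: in this assay compound 2 gives 23000 nM

Compound 2 holds the higher of these two numbers, but its nearest neighbour, compound 1, sits within the usual scatter of it, so the two measurements show no real difference. Compound 3, `Cc1cc(NC(=O)Nc2ccc(Cl)cc2)c2ccccc2n1`, differs from compound 2 only by chloro in place of trifluoromethyl on an aromatic carbon. For the measured compounds named here, no step between measured compounds is available to guide this change, and it is expected to be small in this assay, with the step of a 1.0-fold lower number from compound 2 to compound 3 (0.02 log units; within the scatter) staying within the usual scatter. Compound 3 is therefore estimated at 22000 nM, with a likely range from 9000 nM to 50000 nM.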

Compound 3, half-maximal effective concentration: > 25000 nM
Compound 3 was reported as a limit; the forecaster's own chance of this, stated with the estimate: 10%; at least 1.1-fold (0.05 log units) between middle value and limit.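

In this assay, compound 3 is reported only as a limit: the limit of > 25000 nM in this assay, at which 1 of the 3 values shown sits. Chloro in place of trifluoromethyl on this aromatic carbon gives an at least 1.0-fold higher number from compound 2 to compound 3 (0.03 log units; that floor lies within the scatter), and hydrogen in place of chloro on an aromatic carbon gives an at least 1.4-fold higher number from compound 1 to compound 3 (0.16 log units; that floor lies within the scatter). Both steps are floors within the scatter, so neither change is shown to make a real difference, though neither is ruled out as having one.

Still open, on these data alone, is how far compound 3 really lies past its limit. Also open, as far as these compounds go, is whether an amine or a carboxylic acid at this position would give a step beyond the scatter.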